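Cytotoxicity of Three Measured Amides and One Unmeasured

The compounds below may be only part of what the source reports. "The series", "measured", "known", "first", "only" and "open" are said of these compounds alone.

Compound 1 `O=C(Nc1ccccc1)c1ccc([N+](=O)[O-])o1`: in an ADME assay on HeLa cells (Homo sapiens) for cytotoxicity, read by resazurin assay, with a stated time of 65 h (on this read-out higher numbers stand for an effect only at larger amounts of compound and lower numbers for an effect already at smaller amounts), compound 1 gives > 20000 nM, which is a limit of the assay and not a number.
Compound 2 `O=C(Nc1ccc(C(F)(F)F)cc1)c1ccc([N+](=O)[O-])o1`: in this assay compound 2 gives > 20000 nM, again a limit of the assay.
Compound 3 `O=C(Nc1ccc(O)cc1)c1ccc([N+](=O)[O-])o1`: in this assay compound 3 gives > 20000 nM, also a limit of the assay.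

All three measured compounds therefore sit at the limit of > 20000 nM in this assay, at which 3 of the 3 values shown sit, and none of the changes among them can be read as a step of any size. Going from compound 1 to compound 2 the change is trifluoromethyl in place of hydrogen on an aromatic carbon, and the result is a step that the two limits leave unreadable from compound 1 to compound 2. Going from compound 1 to compound 3 the change is hydroxy in place of hydrogen on an aromatic carbon, with a step that the two limits leave unreadable from compound 1 to compound 3. Between compound 2 and compound 3 the outcome is a step that the two limits leave unreadable from compound 2 to compound 3.

Compound 4 `O=C(Nc1ccc(O)c(C(F)(F)F)c1)c1ccc([N+](=O)[O-])o1` has not been measured. It differs from compound 3 by trifluoromethyl in place of hydrogen on an aromatic carbon. Among the measured compounds shown here, this is the same kind of change as the one from compound 1 to compound 2, but not the same: there the entering group sits para to a large group, whereas here it sits ortho to a hydroxy group and meta to a large group. How the core of compound 3 differs from the core of compound 1 is given by hydroxy in place of hydrogen on an aromatic carbon.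

For compound 4 the expected step is a step that the limit leaves unreadable from compound 3 to compound 4, resting on a step that the two limits leave unreadable from compound 1 to compound 2 and on (the limit of > 20000 nM in this assay, at which 3 of the 3 values shown sit), where every measured compound sits. Compound 4 is thus estimated at 30000 nM, with a range expected from 15000 nM to 100000 nM, and most likely the assay again reports only a limit.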

Compound 4, half-maximal effective concentration: > 20000 nM
Compound 4: only a limit was reported; the forecaster's own chance of this, stated with the estimate: 85%; the middle value is on the limit's open side.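

Compound 3 and compound 4 both stand at a limit of the assay and not at a number, so no step between them can be read, and adding trifluoromethyl shows no measurable size of change: the limit of > 20000 nM in this assay, at which 4 of the 4 values shown sit.

The compounds shown leave open how far past that limit each one lies, and so whether any of these changes on the aromatic ring alters cytotoxicity at all.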